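The source may report more compounds than this note shows. Statements on the series, on what has been measured and on what is new or still open speak of the compounds shown alone.

Measured so far:
Compound 1 `COc1ccc2ncc(S(=O)(=O)c3ccc(Cl)cc3)c(N3CCC(C)CC3)c2c1` gives 91% in an assay on isolated protein for displacement of a labelled ligand from metabotropic glutamate receptor 5 (Homo sapiens), with a stated time of 60 min, tested at 1 uM; a lower number here means less inhibition, a higher number more inhibition at the concentration tested (going by the name of the read-out).
Compound 2 `CC1CCN(c2c(S(=O)(=O)c3ccc(Cl)cc3)cnc3ccc(Cl)cc23)CC1` gives 92% in this assay.

For the measured compounds named here, compound 1 holds the lower of these two numbers, yet its only neighbour is a number 1 percentage points higher from compound 1 to compound 2 (within the scatter), a gap within the scatter, so the two compounds cannot be told apart on these figures. Compound 3 `COc1ccc2ncc(S(=O)(=O)c3cc(Cl)cc(Cl)c3)c(N3CCC(C)CC3)c2c1` has not yet been measured. It differs from compound 1 as follows: 3,5-dichlorophenyl in place of 4-chlorophenyl on a sulfonyl sulfur. Going by the values given here, the single measured step, chloro in place of methoxy on an aromatic carbon of the shared core, concerns a different place in the molecule and therefore says nothing direct about changing the ring that sits on the sulfonyl sulfur. Both measured compounds already inhibit strongly, leaving little room for a rise. Among the compounds with values here, with no step bearing on the change, the expectation for compound 3 is a number 6 percentage points lower from compound 1 to compound 3 (within the scatter), with a modest chance of a drop. Compound 3 is estimated at 85%, within 60% to 97%.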

Compound 3, a percentage reported as inhibition, at one concentration (the size of the read-out at that concentration, not a potency): 87%
Compound 3: the middle estimate sits 2 percentage points below what was measured; the range from low to high includes it.
By their numbers in this assay, from the lowest: compounds 3, 1 and 2 (each within the scatter of the next).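

Swapping 4-chlorophenyl for 3,5-dichlorophenyl on a sulfonyl sulfur gives, in this assay, a number 4 percentage points lower from compound 1 to compound 3 (within the scatter) and is the first measured change at this position. The entering group has 8 heavy atoms against 7 and a second chlorine, yet the two compounds cannot be told apart on these figures, and this read-out is taken at one concentration, so it gives no potency. No measurement on hand explains why the figures stay this close.

On these data alone, it remains open whether an amine or a carboxylic acid on this ring, or a plain methyl group in place of the ring, would shift the number beyond the scatter. Also open, as far as these compounds go, is whether 3,5-dichlorophenyl would give a similar result on the chloro-bearing core of compound 2.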